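This account rests on a few compounds, and the source may have more. Where it says the series, first, only, none or still open, it means among the compounds named here.

Series notes, growth inhibition of a prostate carcinoma line.

Of the compounds shown here, three on a shared core have been measured in a functional assay on PC-3 cells (Homo sapiens) for inhibition, read by MTT assay, with a stated time of 72 h, tested at 1 uM; a higher number here means more inhibition of growth at the concentration tested, a lower number less inhibition of growth. Compound 1 `COc1cc2ncnc(Nc3cc(C(F)(F)F)ccc3F)c2c(OC)c1OC` gives 7.6%. Compound 2 `COc1cc2ncnc(Nc3cc(C(F)(F)F)ccc3Br)c2c(OC)c1OC` gives -3.9%. Compound 3 `COc1cc2ncnc(Nc3ccc(Br)cc3)c2c(OC)c1OC` gives 1%. The values of compound 3 and compound 2 lie within the scatter of each other, as do those of compound 3 and compound 1, so no order is claimed among these. How the core of compound 3 differs from that of compound 2 is not broken down here.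

One step is counted: a number 11.5 percentage points higher from compound 2 to compound 1 (beyond the scatter), the change being (fluoro in place of bromo on an aromatic carbon). The place of that change is on an aromatic carbon of a six-membered aromatic ring of carbon only, ortho to a large group and para to a trifluoromethyl group.

Compound 4 `COc1cc2ncnc(Nc3ccc(F)cc3)c2c(OC)c1OC` has not yet been measured in this assay. It differs from compound 3 by fluoro in place of bromo on an aromatic carbon. This is the same kind of change as from compound 2 to compound 1, but the place differs: here it is para to a large group, with no trifluoromethyl group present. With one step of this kind seen, and that at another place, the expectation rests on a single precedent.

The step expected is a number 7 percentage points higher from compound 3 to compound 4 (within the scatter), set beside the measured step from compound 2 to compound 1. It is tempered because compound 3 gives 1%, which is already low. For compound 4 the estimated value in this assay is 8%, with an expected range from -5% to 21%.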

Compound 4, percent growth inhibition at one concentration: 3.1%
Estimate against measurement, compound 4: 4.9 percentage points above; measured number inside the range.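

Working reading of the change, fluoro in place of bromo on an aromatic carbon: in this assay the new step is a number 2.1 percentage points higher from compound 3 to compound 4 (within the scatter), so on this core the change cannot be told apart from no change, while the earlier step on the other core is a number 11.5 percentage points higher from compound 2 to compound 1 (beyond the scatter). Set side by side, the two steps cannot be told apart either: the same change on two cores in this assay, a number 11.5 percentage points higher (beyond the scatter) from compound 2 to compound 1 and a number 2.1 percentage points higher (within the scatter) from compound 3 to compound 4, 9.4 percentage points apart, within the scatter of two such steps. Going by these compounds alone, this shows that the series holds no evidence of a core dependence for this change, but it does not show that the change carries over with a fixed size, since there are only two steps, each read at a single concentration, and the two cores also differ in whether a trifluoromethyl group is present, an influence these steps cannot separate.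

The compounds shown leave open how a chloro, a nitrile, an amine or a carboxylic acid in the halogen's place on the carbon-only aromatic ring would read in this assay. Also open, on these data alone, is whether the change would behave alike on a core in which a longer chain or a morpholine replaces one of the methoxy groups.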